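This account rests on a few compounds, and the source may have more. Where it says the series, first, only, none or still open, it means among the compounds named here.

Measured compounds in a functional assay on Hep 3B2 cells (Homo sapiens) for inhibition, read by sulforhodamine B assay, with a stated time of 72 h, tested at 10 uM; on this read-out higher numbers stand for more inhibition at the one concentration tested (going by the name of the read-out) and lower numbers for less inhibition:
- compound 1, `C[C@H](Nc1nc(N)nc(N)c1C#N)c1nn(-c2cccc(S(C)(=O)=O)c2)c2cc(F)ccc12`: 36%
- compound 2, `C[C@H](Nc1ncnc2[nH]cnc12)c1nn(-c2cccnc2)c2cc(Cl)ccc12`: 13%
- compound 3, `C[C@H](Nc1nc(N)nc2[nH]cnc12)c1nn(-c2cccnc2)c2cc(F)ccc12`: 14%

Compound 1 stands highest of the three numbers. Compound 3 is nearest to it, yet its value of 14% lies beyond the scatter below compound 1, and compound 2 is furthest, its value of 13% also beyond the scatter below compound 1. Compounds 2 and 3 carry different cores from compound 1 and a different ring on the core nitrogen, so their values describe other molecules and do not isolate any single change.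

Compound 4, `C[C@H](Nc1nc(N)nc(N)c1C#N)c1nn(-c2cccc(S(C)(=O)=O)c2)c2cc(Cl)ccc12`, has not yet been measured. It differs from compound 1 in one place: chloro in place of fluoro on an aromatic carbon. For the measured compounds named here, no pair of measured compounds differs only in this halogen, so the size of such a step in this assay is unknown from these data. A swap of one halogen for another of this kind is expected to move the read-out little, most likely within the scatter, with a slight upward lean. Compound 4 is therefore expected to give 40%, in the range 22% to 58%, a step estimated as a number 4 percentage points higher from compound 1 to compound 4 (within the scatter).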

Compound 4, a percentage reported as inhibition, at one concentration (the size of the read-out at that concentration, not a potency): 72%
For compound 4 the middle estimate is 32 percentage points below the measured one; measured number above the stated range.
By their numbers in this assay, from the lowest: compounds 2 and 3 (each within the scatter of the next); then compound 1; then compound 4.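

In this assay, replacing fluoro with chloro on this aromatic carbon, with the rest of the molecule unchanged, gives a number 36 percentage points higher from compound 1 to compound 4 (beyond the scatter). For the compounds shown here, this shows that the read-out is sensitive to which halogen sits at this position, something the earlier compounds could not show, since they differ from one another in more than one place. Nothing available here explains why this single-atom change has so large an effect.

On these data alone, how a bromo, methyl or methoxy group on this same carbon would read remains open, so it is unclear whether the result is specific to chloro. As far as these compounds go, it is also open whether the same swap would give a similar step on a different core, such as that of compound 3, or with a different ring on the core nitrogen.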